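Fluoro next to methoxy on two stilbene-type cores

The compounds below may be only part of what the source reports. "The series", "measured", "known", "first", "only" and "open" are said of these compounds alone.

This account follows four compounds that share a naphthalene-bearing stilbene-type frame, measured in a functional assay on SK-MEL-28 cells (Homo sapiens) for inhibition; a higher number here means a weaker inhibitor, a lower number a stronger inhibitor. Compound 1 `COc1ccc(/C=C/c2ccc3ccccc3c2)cc1` carries a methoxy group on its phenyl ring. In this assay compound 1 gives > 5000 nM, which is a limit of the assay and not a number. Compound 2 `COc1cccc(/C=C\c2ccc3ccccc3c2)c1` has the same atoms joined differently; the difference between the two cores is not broken down here. In this assay, among the compounds with values here, compound 2 gives 1920 nM, the only number in the set. The values of compound 1 and compound 3 are each a limit of the assay.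

Compound 3 `COc1ccc(/C=C/c2ccc3ccccc3c2)cc1F` differs from compound 1 by fluoro in place of hydrogen on an aromatic carbon. In this assay compound 3 gives > 5000 nM, again a limit of the assay rather than a number. The step that the two limits leave unreadable from compound 1 to compound 3 therefore cannot be sized, since both values rest at the limit of > 5000 nM in this assay, at which 2 of the 3 values shown sit.

Compound 4 `COc1cc(/C=C\c2ccc3ccccc3c2)ccc1F` has not yet been measured. It differs from compound 2 by fluoro in place of hydrogen on an aromatic carbon. This is the same kind of change as that from compound 1 to compound 3, though the new fluoro stands para to a large group in compound 4 and meta to a large group in compound 3. Because the step from compound 1 to compound 3 is unreadable at the limit of > 5000 nM in this assay, at which 2 of the 3 values shown sit, the size expected for a 1.1-fold higher number from compound 2 to compound 4 (0.06 log units; within the scatter) is taken as small. Compound 4 is thus expected to give about 2200 nM, with a likely range from 800 nM to 6500 nM.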

Compound 4, half-maximal inhibitory concentration: 450 nM
Beside the measured number, compound 4's estimate is 4.9-fold (0.69 log units) above it; the measured number lies below the stated range.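

In this assay, fluoro in place of hydrogen on an aromatic carbon, ortho to a methoxy group and para to a large group, gives a 4.3-fold lower number from compound 2 to compound 4 (0.63 log units; beyond the scatter) on the core of compound 2, a modest step beyond the scatter. The matching step on the core of compound 1 cannot be read, since compound 1 and compound 3 both rest at a limit of the assay: the limit of > 5000 nM in this assay, at which 2 of the 4 values shown sit. The lower number is therefore established for the core of compound 2 alone, and the account shows neither that the change carries over from one core to the other nor that it fails to, as one readable step cannot show how the two cores compare in their response.

The compounds shown leave open whether the lower number belongs to fluoro in particular or would also appear with another group in the same place, such as chloro, an amine or a carboxylic acid. They also leave open how much the methoxy group contributes to the step, which a longer chain such as ethoxy or a hydroxyl group in its place could begin to address.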